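Adding a methyl to the carboxyphenyl arm of compound 3

The source may hold more compounds than are shown below. What is called first, only, known or untested is meant among the compounds shown, and "the series" means these compounds.

Measured compounds:
compound 1, `COC(=O)c1ccc(OCCCCOc2ccc(C(=O)CC3CCCC3)c(O)c2C)cc1`, in an assay on HEK293 cells for positive allosteric modulation of metabotropic glutamate receptor 3 (Rattus norvegicus), read by thallium flux, with a stated time of 2.5 min (on this read-out higher numbers stand for an effect only at larger amounts of compound and lower numbers for an effect already at smaller amounts), compound 1 is recorded as "not determined" (no result reported).
compound 2, `Cc1c(OCCCCOc2ccc(C(=O)O)cc2F)ccc(C(=O)CC2CCCC2)c1O`, gives > 10000 nM in this assay; this is a limit of the assay, not a number.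
compound 3, `Cc1c(OCCCCOc2cccc(C(=O)O)c2)ccc(C(=O)CC2CCCC2)c1O`, gives 3400 nM in this assay.

Compound 3 thus stands as the only entry with a single number: of the other two, compound 2 sits at the limit of > 10000 nM in this assay, at which 1 of the 3 values shown sits, and compound 1 has no result at all. For the measured compounds named here, the one measured step, an at least 2.9-fold lower number from compound 2 to compound 3 (0.46 log units; beyond the scatter), moved the carboxy group and removed a fluorine; it is the only step available, and it says nothing about what a methyl does.

Compound 4, `Cc1ccc(C(=O)O)cc1OCCCCOc1ccc(C(=O)CC2CCCC2)c(O)c1C`, differs from compound 3 in one place: methyl in place of hydrogen on an aromatic carbon. Going by the values given here, no measured pair isolates a methyl on this ring, so nothing in the data points to a change in either direction. The expected step is therefore a 1.1-fold lower number from compound 3 to compound 4 (0.03 log units; within the scatter), which is within the scatter. Compound 4 is estimated at 3200 nM in this assay, with a range from 1000 nM to 10000 nM, and the limit of the assay is not far away.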

Compound 4, half-maximal effective concentration: > 10000 nM
Compound 4 gave a limit, no number; the forecaster's own chance of this, stated with the estimate: 25%; middle value at least 3.1-fold (0.49 log units) from the limit.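

A single methyl on the carboxyphenyl arm, ortho to a large group and para to a carboxy group, is not a silent change in this assay: the swap of hydrogen for methyl gives an at least 2.9-fold higher number from compound 3 to compound 4 (0.46 log units; beyond the scatter). The earlier readable step changed the place of the carboxy group and removed a fluorine at once, whereas this pair isolates one added carbon on an aromatic carbon and shows that this position alone can push the number up, with the true size of the step still hidden behind the limit. Compound 4 and compound 2 now both stand at a limit of the assay and not at a number, so the step between them cannot be read: the limit of > 10000 nM in this assay, at which 2 of the 4 values shown sit.

The compounds shown leave open whether the change is specific to methyl or would also follow from a fluorine, a chlorine or a methoxy group on the same aromatic carbon. They also leave open whether an ethyl group there would behave the same way, and whether a methyl elsewhere on this ring would be tolerated.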